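Swapping two chloropyrimidine attachments on a longer linker

This account rests on a few compounds, and the source may have more. Where it says the series, first, only, none or still open, it means among the compounds named here.

Measured compounds:
Compound 1, `Clc1ccc2c(NCCCNc3nccc(Cl)n3)ccnc2c1`, in a physicochemical assay for solubility, read by HPLC, measured as octanol-water partition, at pH 7.4 (a higher number here means a more soluble compound, a lower number a less soluble compound), compound 1 gives 1810 nM.
Compound 2, `Clc1ccc2c(NCCCNc3ccnc(Cl)n3)ccnc2c1`, in this assay compound 2 gives 1010 nM.
Compound 3, `Clc1ccc2c(NCCCCCCCCNc3nccc(Cl)n3)ccnc2c1`, in this assay compound 3 gives 2910 nM.

Compounds 1 and 2 share one core and differ in a single place: 2-chloropyrimidin-4-yl in place of 4-chloropyrimidin-2-yl on an amine nitrogen. This change gave a 1.8-fold lower number from compound 1 to compound 2 (0.25 log units; within the scatter). Compound 3 has a different core from compound 1; the difference between the two cores is not broken down here. Among the three measured values, the number for compound 3 sits highest, and its gap to compound 2 lies beyond the scatter, while its gap to compound 1 lies within it.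

Compound 4, `Clc1ccc2c(NCCCCCCCCNc3ccnc(Cl)n3)ccnc2c1`, has not yet been measured in this assay. It stands to compound 3 as compound 2 stands to compound 1: 2-chloropyrimidin-4-yl in place of 4-chloropyrimidin-2-yl on an amine nitrogen. The place is the same in both pairs, an amine nitrogen whose other neighbour is a saturated chain carbon, so this is the same change made on a second core.

Among the measured compounds shown here, with only one earlier instance to go on, the expectation for compound 3 to compound 4 is a step of the same size, a 1.8-fold lower number from compound 3 to compound 4 (0.25 log units; within the scatter), because compound 1 to compound 2 showed a 1.8-fold lower number from compound 1 to compound 2 (0.25 log units; within the scatter). On that basis compound 4 is estimated at 1620 nM, with a likely range from 900 nM to 2900 nM, the width reflecting that a single earlier step within the scatter is a weak guide.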

Compound 4, solubility: 2410 nM
Beside the measured number, compound 4's estimate is 1.5-fold (0.17 log units) below it; the measured number falls inside the stated range.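

In this assay, the same swap, 2-chloropyrimidin-4-yl in place of 4-chloropyrimidin-2-yl on an amine nitrogen, now has a second reading on a second core (a 1.2-fold lower number from compound 3 to compound 4 (0.08 log units; within the scatter)), to set beside the first (a 1.8-fold lower number from compound 1 to compound 2 (0.25 log units; within the scatter)). Both steps lie within the usual scatter of repeated measurements, so on each core the swap cannot be told apart from no change at all, and that is the one consistent finding: across these two pairs, the result carries over as a step too small to read. This does not prove that the two attachments are truly equivalent, since a small real difference could hide inside the scatter, and two pairs cannot establish a rule for the series, while no measurement shown here speaks to why the steps are this small.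

The compounds shown leave open whether the swap stays this small on a chain longer than the one in compound 3, or when an amine takes the place of the chlorine on the pyrimidine ring. A pair with either feature would test whether the swap remains unreadable once the rest of the molecule changes further.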